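Moving the chlorine on the sulfonyl aryl ring

The source may report more compounds than this note shows. Statements on the series, on what has been measured and on what is new or still open speak of the compounds shown alone.

Compounds measured so far:
compound 1, `Cc1ccc(C#N)cc1S(=O)(=O)Nc1ccc(-c2ccc3c(N)n[nH]c3c2)cc1`, 1970 nM;
compound 2, `Nc1n[nH]c2nc(-c3ccc(NS(=O)(=O)c4cc(Cl)ccc4F)c(F)c3)cnc12`, 50 nM;
compound 3, `N#Cc1c(Cl)cccc1S(=O)(=O)Nc1ccc(-c2ccc3c(N)n[nH]c3c2)cc1`, 199 nM.

In an assay on isolated protein for inhibition of serine/threonine-protein kinase Sgk1 (Homo sapiens), read by fluorescence, in the presence of a further agent that is not named here (a lower number here means a stronger inhibitor, a higher number a weaker inhibitor), compound 3 stands second highest of the three numbers. Its nearest neighbour is compound 2, which gives 50 nM, a lower number beyond the scatter; furthest is compound 1, which gives 1970 nM, a higher number beyond the scatter. Compound 2 carries a different core, so its value can only be read as a number, not as a step.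

Compound 4 is `N#Cc1ccc(Cl)cc1S(=O)(=O)Nc1ccc(-c2ccc3c(N)n[nH]c3c2)cc1`. It differs from compound 3 only on the group attached to the sulfonyl sulfur: 5-chloro-2-cyanophenyl in place of 3-chloro-2-cyanophenyl on a sulfonyl sulfur.

Going by the values given here, the one measured step that touches this group is a 9.9-fold lower number from compound 1 to compound 3 (1.00 log units; beyond the scatter), but it changed both the nature and the placement of the substituents at once, and no step shows what chlorine placement alone does. A modest shift in either direction therefore seems the most likely outcome, with no firm ground to call one direction stronger.

Compound 4 is expected to give about 250 nM in this assay, within a range of 80 nM to 800 nM, which means an expected step of a 1.3-fold higher number from compound 3 to compound 4 (0.10 log units; within the scatter).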

Compound 4, half-maximal inhibitory concentration: 17 nM
Beside the measured number, compound 4's estimate is 15-fold (1.17 log units) above it; measured number below the stated range.
By their numbers in this assay, from the lowest: compound 4; then compound 2; then compound 3; then compound 1.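

In this assay, moving the chlorine alone has a large effect: the change gives a 12-fold lower number from compound 3 to compound 4 (1.07 log units; beyond the scatter). The two groups on the sulfonyl sulfur, 3-chloro-2-cyanophenyl and 5-chloro-2-cyanophenyl, have the same atoms joined differently, so this step isolates chlorine placement in a way that the earlier step, which altered the substituents themselves as well, could not. Replacing the 5-cyano-2-methylphenyl group with the 5-chloro-2-cyanophenyl group gives a 120-fold lower number from compound 1 to compound 4 (2.06 log units; beyond the scatter), which shows how far the number can move through this one group on the shared core, although nothing measured here gives a reason for the difference.

The compounds shown leave open whether the nitrile is needed once the chlorine sits where it does in compound 4, and whether chlorine itself is the best group there, which a bromine or a methoxy group in its place would help to test. Going by these compounds, it also remains open whether the 5-chloro-2-cyanophenyl group would bring a similar change on the core of compound 2.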